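The source may hold more compounds than are shown below. What is called first, only, known or untested is meant among the compounds shown, and "the series" means these compounds.

Of the compounds shown here, two have been measured in a functional assay on the whole organism for inhibition, with Rattus norvegicus as the target; a higher number here means that more compound is needed for the effect, a lower number that less compound is needed. Compound 1, `C[C@H]1CC/C(=N\Nc2ccc(O)cc2)c2ncc(C(=O)O)c(=O)n21`, is the weaker of the pair: in this assay compound 1 gives 111 umol/kg. Compound 2, `CCOc1ccc(N/N=C2\CC[C@@H](C)n3c2ncc(C(=O)O)c3=O)cc1`, stands lowest of the two numbers; in this assay compound 2 gives 0.2 umol/kg, a gap from compound 1 that lies well beyond the usual scatter.

Compound 3, `CCOc1ccc(N/N=C2\CC[C@H](C)n3c2ncc(C(=O)O)c3=O)cc1`, has not been measured. Its relation to compound 2 is narrow: the two compounds have the same atoms and bonds and differ only in configuration as drawn: 1 of 2 stereo elements differ; a stereocentre at a saturated ring carbon is drawn R in compound 2 and S in compound 3. Within the data shown here, no measured pair in this set shows what such a change in configuration alone does here, so the direction can only be guessed from general experience, where the two drawn forms of a stereocentre frequently differ markedly, and one of them carries most of the effect. Since compound 2 gives 0.2 umol/kg, the other form is expected to need more compound, and the step of a 15-fold higher number from compound 2 to compound 3 (1.18 log units; beyond the scatter) is expected to reach beyond the scatter. Compound 3 is therefore estimated at 3 umol/kg, with a range from 0.3 umol/kg to 50 umol/kg.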

Compound 3, dose for 50% inhibition: 100 umol/kg
Beside the measured number, compound 3's estimate is 33-fold (1.52 log units) below it; measured number outside the range, above it.
By their numbers in this assay, from the lowest: compound 2; then compounds 3 and 1 (each within the scatter of the next).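

In this assay, the configuration at this saturated ring carbon decides nearly everything, with a 500-fold higher number from compound 2 to compound 3 (2.70 log units; beyond the scatter). The source of so large a gap can be stated exactly: the fact that compounds 2 and 3 differ only in the configuration as drawn With the centre drawn S, ethyl in place of hydrogen on the oxygen on the aromatic ring changes nothing beyond the scatter, with a 1.1-fold lower number from compound 1 to compound 3 (0.05 log units; within the scatter), so the ethyl group alone gives no gain in that form, and the low number of compound 2 appears only with ethyl and the R form together.

Whether ethyl in place of hydrogen on that oxygen matters with the centre drawn R remains an open question. Also open, as far as these compounds go, is whether a longer chain such as propyl on that oxygen, or an amine on the aromatic ring in place of the ethyl-bearing oxygen, would keep the number as low as in compound 2.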